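The source may hold more compounds than are shown below. What is called first, only, known or untested is meant among the compounds shown, and "the series" means these compounds.

Measured compounds:

compound 1 `CC1=C(C(=O)Nc2ccc(F)cc2)C(c2ccc([N+](=O)[O-])cc2)N=C(SCc2ccccc2)N1`; in a functional assay on the whole organism (artery, strain albino) with Rattus norvegicus as the target, with a stated time of 900 min, at a dose of 10 mg/kg by the oral route (a lower number here means less inhibition, a higher number more inhibition at the dose given (going by the name of the read-out)), compound 1 gives 21%
compound 2 `CC1=C(C(=O)Nc2ccc(Br)cc2)C(c2ccc(Cl)cc2Cl)N=C(SCc2ccccc2)N1`; in this assay compound 2 gives 8.2%

Among the compounds with values here, compound 2 stands lowest of the two numbers measured so far in this assay. Its nearest neighbour is compound 1, whose number lies higher by a margin beyond the usual scatter. Within the data shown here, the two compounds differ in several places at once, so no single step between them can be read out; only their two values can be set side by side.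

Compound 3 `CC1=C(C(=O)Nc2ccc(Br)cc2)C(c2ccc(Cl)cc2Cl)N=C(SCc2ccc(Cl)cc2)N1` has not yet been measured in this assay. It differs from compound 2 in one place: chloro in place of hydrogen on an aromatic carbon. The change sits on the benzyl group attached to the sulfur, on an aromatic carbon of a six-membered aromatic ring of carbon only, para to a large group.

Among the measured compounds shown here, no measured pair isolates this change, so there is nothing to anchor its direction. The working expectation is a step from compound 2 to compound 3 in this assay of a number 1.8 percentage points higher from compound 2 to compound 3 (within the scatter), not beyond the scatter in either direction. On that basis compound 3 is estimated at 10% in this assay, with a range from 0% to 25%.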

Compound 3, a percentage reported as inhibition, in the whole organism at one dose (the size of the read-out at that dose, not a potency): 22.1%
Compound 3: middle estimate off by 12.1 percentage points, on the low side, within the range that was stated.
By their numbers in this assay, from the lowest: compound 2; then compounds 1 and 3 (each within the scatter of the next).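

Going from benzyl to 4-chlorobenzyl on the sulfur, with the rest of the molecule unchanged, gives a number 13.9 percentage points higher from compound 2 to compound 3 (beyond the scatter) in this assay. Within the data shown here, this is the first step that can be read at a single place, and it shows that this aromatic carbon of the benzyl group is not silent: one chloro in place of hydrogen, para to a large group, moves the read-out by a modest amount that still lies beyond the usual scatter. Nothing at hand bears on why the number moves in this direction.

This single step, read on the background of compound 2 at one dose and one time, leaves open whether the same change would move the number in the same direction on the background of compound 1. It also leaves open whether the step belongs to chloro itself or would appear with another group in that same place, such as a methoxy group, an amine or a carboxylic acid.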